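A Group Swap on the Carbonyl Carbon of Compound 3

The source may report more compounds than this note shows. Statements on the series, on what has been measured and on what is new or still open speak of the compounds shown alone.

Compound 1 `Cc1ccccc1S(=O)(=O)c1ccc(CNC(=O)c2cc3cnccc3[nH]2)cc1` gives 15%
Compound 2 `O=C(NCc1ccc(S(=O)(=O)c2ccccc2)cc1)c1ccc2ncncc2c1` gives 3.7%
Compound 3 `O=C(NCc1ccc(S(=O)(=O)c2ccccc2)cc1)c1cc2ncccc2s1` gives 1.6%

In an ADME assay on microsomes from liver (Mus musculus) for metabolic stability, read by LC-MS, with a stated time of 30 min, tested at 1 uM (on this read-out lower numbers stand for a less stable compound and higher numbers for a more stable compound), compound 3 gives 1.6% as its reading, within the usual scatter of compound 2 and beyond the scatter from compound 1. Compound 4 `O=C(NCc1ccc(S(=O)(=O)c2ccccc2)cc1)c1ccc2nccn2c1` keeps the rest of compound 3 and changes only the group on the carbonyl carbon (a group of 9 heavy atoms (7 carbon, 2 nitrogen; one five-membered aromatic ring with 2 hetero atoms, one six-membered aromatic ring with 1 hetero atom) in place of a group of 9 heavy atoms (7 carbon, 1 nitrogen, 1 sulfur; one five-membered aromatic ring with 1 hetero atom, one six-membered aromatic ring with 1 hetero atom), on a carbonyl carbon). For the measured compounds named here, no measured pair differs in one place only, so this change has no direct precedent. Compound 2 at 3.7% carries a different group there, yet compound 3 at 1.6% stays within its scatter. The expected move is therefore small (a number 2.4 percentage points higher from compound 3 to compound 4 (within the scatter)) and not beyond the scatter. For compound 4 the estimated value is 4% with an expected range of 1% to 15% around it.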

Compound 4, percent of the compound remaining: 18%
The estimate for compound 4 lay 14 percentage points below the measured number; the whole stated range lies below it.
By their numbers in this assay, from the lowest: compounds 3 and 2 (each within the scatter of the next); then compounds 1 and 4 (each within the scatter of the next).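

In this assay, the group on the carbonyl carbon matters: swapping one group for another of the same heavy-atom count gives a number 16.4 percentage points higher from compound 3 to compound 4 (beyond the scatter). The two groups also match in hydrogen-bond donors, hydrogen-bond acceptors and net charge, so these counts do not account for the step. Nothing measured here explains the difference.

On these data alone, whether the step follows from losing the sulfur or from the second nitrogen in the five-membered ring remains open. So does how a simple phenyl group would behave on this carbonyl carbon.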